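Inverting one chain stereocentre in a clearance series

The compounds below may be only part of what the source reports. "The series", "measured", "known", "first", "only" and "open" are said of these compounds alone.

Of the compounds shown here, three sharing one core have been measured in an ADME assay on the whole organism (strain Wistar) for pharmacokinetics, with Rattus norvegicus as the target, given by the intravenous route; on this read-out lower numbers stand for slow clearance and higher numbers for fast clearance. Compound 1 `Cc1cn([C@H]2CCCN([C@H](CC(C)C)c3ccc(C(=O)O)c(Oc4cccc(Cl)c4)c3F)C2)c(=O)[nH]c1=O` gives 84 mL/min/kg, and compound 2 `CC[C@H](c1ccc(C(=O)O)c(Oc2cccc(Cl)c2)c1F)N1CCC[C@H](n2cc(C)c(=O)[nH]c2=O)C1` gives 119 mL/min/kg. Compound 3 `CCC[C@@H](c1ccc(C(=O)O)c(Oc2cccc(Cl)c2)c1F)N1CCC[C@H](n2cc(C)c(=O)[nH]c2=O)C1` gives 18 mL/min/kg, the lowest of the three numbers and beyond the scatter from both of the others.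

The next compound, compound 4 `CCC[C@H](c1ccc(C(=O)O)c(Oc2cccc(Cl)c2)c1F)N1CCC[C@H](n2cc(C)c(=O)[nH]c2=O)C1`, keeps every atom and bond of compound 3: the two compounds have the same atoms and bonds and differ only in configuration as drawn: 1 of 2 stereo elements differ; a stereocentre at a saturated chain carbon is drawn S in compound 3 and R in compound 4. Among the compounds with values here, no measured step inverts a stereocentre, so none gauges this change directly. Within the data shown here, the only measured step, methyl in place of isopropyl on a saturated chain carbon, is a 1.4-fold higher number from compound 1 to compound 2 (0.15 log units; within the scatter). That step shows one chain change leaving the number within the scatter, while compound 3 stands well apart from that pair. A rise beyond the scatter is therefore expected in this assay, towards the higher pair, though the lack of a direct precedent keeps this uncertain. The expected change is a 3.9-fold higher number from compound 3 to compound 4 (0.59 log units; beyond the scatter). For compound 4 the estimated clearance is 70 mL/min/kg, with an expected range from 28 mL/min/kg to 130 mL/min/kg.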

Compound 4, clearance: 64 mL/min/kg
Beside the measured number, compound 4's estimate is 1.1-fold (0.04 log units) above it, within the range that was stated.
By their numbers in this assay, from the lowest: compound 3; then compounds 4, 1 and 2 (each within the scatter of the next).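

In this assay, inverting this stereocentre gives a 3.6-fold higher number from compound 3 to compound 4 (0.55 log units; beyond the scatter), the first measured sign that the configuration at this saturated chain carbon can move clearance beyond the scatter, and the gap can be traced to that configuration alone: the fact that compounds 3 and 4 differ only in the configuration as drawn The chain steps around compound 4 behave differently, with a 1.9-fold lower number from compound 2 to compound 4 (0.27 log units; within the scatter) and a 1.3-fold lower number from compound 1 to compound 4 (0.12 log units; within the scatter), both within the scatter. Compounds 1, 2 and 4 therefore form one group whose chain differences leave the number within the scatter, and compound 3 is the one that goes against this grouping.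

The compounds shown leave open whether the configuration of compound 3 would also give slow clearance with a different chain at this carbon, such as a butyl or cyclopropylmethyl group. They also leave open what underlies the gap between compound 3 and compound 4, and whether it would survive replacing the carboxylic acid with a primary amide.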